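The source may report more compounds than this note shows. Statements on the series, on what has been measured and on what is new or still open speak of the compounds shown alone.

Three compounds share one core and differ only in the aryl group on the nitrogen on an aromatic ring. Compound 1 `COc1ccccc1Nc1nc(SCc2ccc(C(F)(F)F)cc2)nc2ccccc12` carries a 2-methoxyphenyl there; in a functional assay on HGC-27 cells (Homo sapiens) for cytotoxicity, read by MTT assay, with a stated time of 72 h (a lower number here means a stronger inhibitor, a higher number a weaker inhibitor), compound 1 gives only a limit, > 50000 nM, which is the limit of > 50000 nM in this assay, at which 1 of the 3 values shown sits. Compound 2 `FC(F)(F)c1ccc(CSc2nc(Nc3cccc(Cl)c3)c3ccccc3n2)cc1` carries a 3-chlorophenyl and in this assay compound 2 gives 19900 nM. Compound 3 `O=[N+]([O-])c1ccc(Nc2nc(SCc3ccc(C(F)(F)F)cc3)nc3ccccc23)cc1` carries a 4-nitrophenyl and in this assay compound 3 gives 16600 nM, the lowest of the two numbers, though the gap between them is a 1.2-fold lower number from compound 2 to compound 3 (0.08 log units; within the scatter), within the scatter. The step of an at least 3.0-fold lower number from compound 1 to compound 3 (0.47 log units; beyond the scatter) is beyond the scatter, but it starts from a limit.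

Compound 4 `Cc1ccc(Nc2nc(SCc3ccc(C(F)(F)F)cc3)nc3ccccc23)cc1` is not yet measured. Its change from compound 3 is methyl in place of nitro on an aromatic carbon. Within the data shown here, no measured step exchanges a nitro for a methyl, and the one comparison among numbers, a 1.2-fold lower number from compound 2 to compound 3 (0.08 log units; within the scatter), lies within the scatter, so no step beyond the scatter is expected in this assay. Compound 4 is therefore estimated at 22000 nM, between 8000 nM and 60000 nM, meaning a step of a 1.3-fold higher number from compound 3 to compound 4 (0.12 log units; within the scatter).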

Compound 4, half-maximal inhibitory concentration: 34600 nM
Compound 4: the middle estimate sits 1.6-fold (0.20 log units) below what was measured, and the stated range covers the measured number.
By their numbers in this assay, from the lowest: compounds 3, 2 and 4 (each within the scatter of the next, the first and the last beyond it). At a limit, above all of these: compound 1.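

Among these compounds, the step of a 2.1-fold higher number from compound 3 to compound 4 (0.32 log units; beyond the scatter) is the only measured exchange on this aromatic carbon, para to a large group, and it shows in this assay that methyl in place of nitro changes the number modestly, though beyond the scatter. The step of a 1.7-fold higher number from compound 2 to compound 4 (0.24 log units; within the scatter) stays within the scatter, so 4-methylphenyl and 3-chlorophenyl are not told apart here. The step of an at least 1.4-fold lower number from compound 1 to compound 4 (0.15 log units; that floor lies within the scatter) cannot be read as a size, because compound 1 stands only at a limit: the limit of > 50000 nM in this assay, at which 1 of the 4 values shown sits.

On these data alone, whether an amine, a carboxylic acid or a longer chain on this same carbon would bring the number much lower remains open. Also open, as far as these compounds go, is whether the exchange of nitro for methyl gives a similar step on the other carbons of this ring.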